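The source may hold more compounds than are shown below. What is called first, only, known or untested is meant among the compounds shown, and "the series" means these compounds.

Working notes on the para-substituted series.

Compound 1 `C#Cc1ccc(S(=O)(=O)Nc2cccc(-c3csc(NC(C)=O)n3)c2)cc1` carries the bare terminal alkyne on the shared core. In a functional assay on A-375 cells (Homo sapiens) for antiproliferative activity, read by trypan blue exclusion, with a stated time of 48 h, tested at 10 uM (on this read-out lower numbers stand for a stronger effect and higher numbers for a weaker effect at the one concentration tested), compound 1 gives 1.2%. Compound 2 `CCCCCCCCC#Cc1ccc(S(=O)(=O)Nc2cccc(-c3csc(NC(C)=O)n3)c2)cc1` bears an octyl on the triple-bonded carbon. In this assay compound 2 is reported only as a limit, < 1%. Compound 3 `CCCCCC/C=C\c1ccc(S(=O)(=O)Nc2cccc(-c3csc(NC(C)=O)n3)c2)cc1` carries instead the eight-carbon chain with one double bond outside the aromatic rings. In this assay compound 3 is likewise reported only as a limit, <= 1%.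

The measured steps are a number at least 0.2 percentage points lower from compound 1 to compound 2 (that floor lies within the scatter) and a number at least 0.2 percentage points lower from compound 1 to compound 3 (that floor lies within the scatter), while a step that the two limits leave unreadable from compound 2 to compound 3. Compound 3 thus stands at the floor of the read-out, (the limit of <= 1% in this assay, at which 1 of the 3 values shown sits), with compound 2 at the neighbouring floor (the limit of < 1% in this assay, at which 1 of the 3 values shown sits), and compound 1 within the scatter of both. All three compounds sit at or next to the lowest value the read-out reports.

Compound 4 `CCCCCCCCc1ccc(S(=O)(=O)Nc2cccc(-c3csc(NC(C)=O)n3)c2)cc1` differs from compound 3 by a group of 8 heavy atoms (8 carbon; no ring) in place of a group of 8 heavy atoms (8 carbon; no ring), on an aromatic carbon. Among the compounds with values here, the steps that bear on it, from compound 1 to compounds 2 and 3, both end at a limit and were at most the size of the scatter. A saturated octyl on the same aromatic carbon is therefore expected to leave the read-out unchanged beyond the scatter, a number no lower from compound 3 to compound 4 (the limit leaves the size open). For compound 4 the expected value in this assay is 1%, between 0.3% and 5%, most likely again reported only as a limit.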

Compound 4, a percentage reported as activity, at one concentration (the size of the read-out at that concentration, not a potency): < 1%
Compound 4: only a limit was reported; the forecaster's own chance of this, stated with the estimate: 60%; the middle value lies on the limit itself.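

Octyl on the aromatic carbon para to a large group, a chain with no double bond outside the aromatic rings, leaves compound 4 at a limit in this assay, so among the listed compounds neither the triple bond of compound 2 nor the double bond of compound 3 is required to reach the floor of the read-out. Measured against the bare terminal alkyne, the change gives a number at least 0.2 percentage points lower from compound 1 to compound 4 (that floor lies within the scatter), and the steps among compound 2, compound 3 and compound 4 cannot be read, as each of the three is reported only as a limit. Compound 4 shares its reported limit with compound 2: the limit of < 1% in this assay, at which 2 of the 4 values shown sit.

With all four compounds at or within the scatter of the floor, this single concentration does not separate the bare terminal alkyne from the longer chains, so no ordering of the chains at this position can be drawn. As far as these compounds go, whether a butyl chain, an amine or a carboxylic acid on the same aromatic carbon would lift the read-out clear of the floor stays open.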